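Methoxymethyl to ethyl on the pyrimidine of compound 3

This account rests on a few compounds, and the source may have more. Where it says the series, first, only, none or still open, it means among the compounds named here.

Three compounds of the series have been run in a functional assay on isolated protein for agonist activity at Glucose-dependent insulinotropic receptor (Mus musculus), read by cAMP accumulation; on this read-out lower numbers stand for an effect already at smaller amounts and higher numbers for an effect only at larger amounts of compound. Compound 1 `CC(C)c1noc(N2CCC([C@H]3C[C@H]3COCc3ccc(S(C)(=O)=O)cc3F)CC2)n1` gives 9.9 nM in this assay. Compound 2 `CC1(OC(=O)N2CCC([C@H]3C[C@H]3COCc3ccc(-n4cnnn4)cc3F)CC2)CC1` gives 15 nM. Compound 3 `COCc1cnc(N2CCC([C@H]3C[C@H]3COCc3ccc(S(C)(=O)=O)c(F)c3)CC2)nc1` gives 5.2 nM, the lowest number of the three; compound 1 lies within the scatter of it, whereas compound 2 sits beyond the scatter. No pair among these three differs in a single place, so no measured single step is available.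

Compound 4 `CCc1cnc(N2CCC([C@H]3C[C@H]3COCc3ccc(S(C)(=O)=O)c(F)c3)CC2)nc1` differs from compound 3 by methyl in place of methoxy on a saturated chain carbon bound to an aromatic carbon. Among the compounds with values here, with no comparable step on record, the expected change from compound 3 to compound 4 is small, a 1.3-fold higher number from compound 3 to compound 4 (0.13 log units; within the scatter), within the scatter in either direction. For compound 4 the expected value is 7 nM, between 2.5 nM and 20 nM.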

Compound 4, half-maximal effective concentration: 5.5 nM
Compound 4: the middle estimate sits 1.3-fold (0.10 log units) above what was measured, and the stated range covers the measured number.
By their numbers in this assay, from the lowest: compounds 3, 4, 1 and 2 (each within the scatter of the next, the first and the last beyond it).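

In this assay, the series now has its first single-place step, and a 1.1-fold higher number from compound 3 to compound 4 (0.02 log units; within the scatter) puts the two compounds within the scatter of each other. On the saturated chain carbon bound to an aromatic carbon, methoxy and methyl therefore cannot be told apart, so the hydrogen-bond acceptor that leaves with methoxy shows no measurable cost on this read-out. No measurement on hand bears on the reason for this result. From the compounds shown here alone, whether the same holds for an amine, a carboxylic acid or a longer chain at this place remains open. So does whether methyl and methoxy stay equivalent on the other cores shown.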